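Working notes: fluoro step from compound 3 to compound 4

A few compounds are considered here, and "the series" means these few. Any claim that something is new, unique, unknown or untested is made for them only; others in the source may bear on it.

- compound 1 `CC(O)(COc1ccc(C(F)(F)F)cc1)C(=O)Nc1cccc(S(F)(F)(F)(F)F)c1` gives 9600 nM
- compound 2 `CC(O)(COc1ccccc1C(F)(F)F)C(=O)Nc1cccc(S(F)(F)(F)(F)F)c1` gives 26300 nM
- compound 3 `CC(O)(COc1ccc(C#N)cc1)C(=O)Nc1cccc(S(F)(F)(F)(F)F)c1` gives 30000 nM
- compound 4 `CC(O)(COc1ccc(C#N)c(F)c1)C(=O)Nc1cccc(S(F)(F)(F)(F)F)c1` is not yet measured

In a functional assay on LNCaP cells (Homo sapiens) for antiproliferative activity, read by propidium iodide staining, with a stated time of 96 h (on this read-out lower numbers stand for stronger inhibition and higher numbers for weaker inhibition), compound 3 gives 30000 nM and shares the weak end of the set with compound 2, the gap being a 1.1-fold higher number from compound 2 to compound 3 (0.06 log units; within the scatter) only. For the measured compounds named here, compound 4 differs through fluoro in place of hydrogen on an aromatic carbon as its single change: fluoro in place of hydrogen on an aromatic carbon, ortho to a cyano group. Going by the values given here, no measured step makes this change. The nearest evidence is two changes of ring substitution, a 3.1-fold higher number from compound 1 to compound 3 (0.49 log units; beyond the scatter) and a 2.7-fold higher number from compound 1 to compound 2 (0.44 log units; beyond the scatter), both modest. In this assay, on these data alone, no step beyond the scatter is therefore expected, and the direction stays open. The estimated step is a 1.4-fold lower number from compound 3 to compound 4 (0.13 log units; within the scatter) on this reading. For compound 4 the estimate is 22000 nM, with an expected range of 9000 nM to 50000 nM in this series.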

Compound 4, half-maximal inhibitory concentration: 83700 nM
Estimate against measurement, compound 4: 3.8-fold (0.58 log units) below, outside the stated range (above it).
By their numbers in this assay, from the lowest: compound 1; then compounds 2 and 3 (each within the scatter of the next); then compound 4.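

In this assay fluoro in place of hydrogen, ortho to a cyano group, is not a silent change: it gives a 2.8-fold higher number from compound 3 to compound 4 (0.45 log units; beyond the scatter) and so weakens inhibition beyond the scatter. With a 3.2-fold higher number from compound 2 to compound 4 (0.50 log units; beyond the scatter) and an 8.7-fold higher number from compound 1 to compound 4 (0.94 log units; beyond the scatter) the 4-cyano-3-fluorophenyl group gives the weakest inhibition of the four compounds shown. On these data alone, whether a chlorine atom or a methyl group at this place would shift the number in the same direction stays open, as does the effect of fluoro on the 4-(trifluoromethyl)phenyl group. No supporting data bear on why this step occurs.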